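A few compounds are considered here, and "the series" means these few. Any claim that something is new, unique, unknown or untested is made for them only; others in the source may bear on it.

Measured compounds:
compound 1 `CCCn1c(=O)c2nc(-c3cnn(Cc4cc(C(F)(F)F)ccc4Cl)c3)[nH]c2n(CCC)c1=O`, 22 nM;
compound 2 `CCCn1c(=O)c2nc(-c3cnn(Cc4ccc(OC)c(C(F)(F)F)c4)c3)[nH]c2n(CCC)c1=O`, 410 nM;
compound 3 `CCCn1c(=O)c2nc(-c3cnn(Cc4ccccc4OC)c3)[nH]c2n(CCC)c1=O`, 37 nM.

All three share the same core and differ only in the aromatic ring carried on a saturated chain carbon bound to an aromatic nitrogen. In an in vitro assay on HEK293 cells for displacement of a labelled ligand from adenosine receptor A2b (Homo sapiens) (on this read-out higher numbers stand for weaker inhibition and lower numbers for stronger inhibition), compound 3 stands second highest of the three numbers: compound 1 sits nearest, and compound 2 furthest. For the measured compounds named here, the one measured step that touches compound 3 is a 1.7-fold higher number from compound 1 to compound 3 (0.23 log units; within the scatter), which shows that exchanging the whole ring can leave the number about where it was. Compound 4 `CCCn1c(=O)c2nc(-c3cnn(Cc4ccc(F)c(C(F)(F)F)c4)c3)[nH]c2n(CCC)c1=O` is the next variation: 4-fluoro-3-(trifluoromethyl)phenyl in place of 2-methoxyphenyl on a saturated chain carbon bound to an aromatic nitrogen. Going by the values given here, no step directly joins compound 2 to compound 3 or to compound 4, but the ring entering in compound 4 matches that of compound 2 in all but one substituent, and compound 2 gives 410 nM while compound 3 gives 37 nM. Among the compounds with values here, the expectation is therefore a step upward, a 5.4-fold higher number from compound 3 to compound 4 (0.73 log units; beyond the scatter), with a broad range because only one related comparison exists. For compound 4 the estimate in this assay is 200 nM, between 60 nM and 700 nM.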

Compound 4, inhibition constant: 640 nM
Compound 4: the middle estimate sits 3.2-fold (0.51 log units) below what was measured; measured number inside the range.
By their numbers in this assay, from the lowest: compounds 1 and 3 (each within the scatter of the next); then compounds 2 and 4 (each within the scatter of the next).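

Replacing the ring at this position is not always harmless: in this assay, the exchange for 4-fluoro-3-(trifluoromethyl)phenyl gives a 17-fold higher number from compound 3 to compound 4 (1.24 log units; beyond the scatter) and a 29-fold higher number from compound 1 to compound 4 (1.46 log units; beyond the scatter), both large steps. A trifluoromethyl group alone does not go with the higher numbers, since compound 1 carries one and still gives a low number, so the rest of the ring's substitution must be considered as well. With fluoro in place of methoxy on an aromatic carbon, the result is a 1.6-fold higher number from compound 2 to compound 4 (0.19 log units; within the scatter), within the scatter, so this exchange does not tell compound 2 and compound 4 apart.

From the compounds shown here alone, whether a ring carrying an amine or a carboxylic acid would give a number near that of compound 3 remains open. The compounds shown include no evidence on why these rings give such different numbers.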